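The source may hold more compounds than are shown below. What is called first, only, known or untested is meant among the compounds shown, and "the series" means these compounds.

Three analogues built on one shared core have been measured in a functional assay on T47D cells (Homo sapiens) for inhibition, read by sulforhodamine B assay, with a stated time of 48 h; on this read-out higher numbers stand for weaker inhibition of growth and lower numbers for stronger inhibition of growth. Compound 1 `COC(=O)[C@@]1(C)CCC=C2[C@@H]1CC[C@@H](C)[C@]2(C)Cc1c[nH]c2ccccc12` gives 4200 nM. Compound 2 `COC(=O)[C@@]1(C)CCC=C2[C@@H]1CC[C@@H](C)[C@]2(C)Cc1c[nH]c2ccc(F)cc12`, which carries a fluoro on an aromatic carbon, gives 3900 nM, and the step of a 1.1-fold lower number from compound 1 to compound 2 (0.03 log units; within the scatter). Compound 3 `COC(=O)[C@@]1(C)CCC=C2[C@@H]1CC[C@@H](C)[C@]2(C)Cc1c[nH]c2c(C)cccc12`, which carries a methyl on an aromatic carbon, gives 18000 nM. Compound 3 therefore stands with the highest number of the three, both others lying lower by steps beyond the scatter, and the step of a 4.3-fold higher number from compound 1 to compound 3 (0.63 log units; beyond the scatter).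

Compound 4 `COC(=O)[C@@]1(C)CCC=C2[C@@H]1CC[C@@H](C)[C@]2(C)Cc1c[nH]c2c(Br)cccc12` has not yet been measured. It differs from compound 3 by bromo in place of methyl on an aromatic carbon. For the measured compounds named here, no measured step exchanges one substituent for another at the same aromatic carbon, so the evidence is indirect. The step of a 4.3-fold higher number from compound 1 to compound 3 (0.63 log units; beyond the scatter) shows that the methyl of compound 3 costs growth inhibition relative to hydrogen, while the step of a 1.1-fold lower number from compound 1 to compound 2 (0.03 log units; within the scatter) shows that a halogen replacing hydrogen left the number unchanged within the scatter. Whether bromo will behave more like methyl or more like hydrogen cannot be settled from these numbers, so the expected step of a 1.6-fold lower number from compound 3 to compound 4 (0.21 log units; within the scatter) is a small move toward a lower number, not clearly beyond the scatter. Compound 4 is thus expected to give about 11000 nM in this assay, with a range from 3500 nM to 35000 nM.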

Compound 4, concentration for 50% growth inhibition: 24000 nM
Beside the measured number, compound 4's estimate is 2.2-fold (0.34 log units) below it, within the range that was stated.
By their numbers in this assay, from the lowest: compounds 2 and 1 (each within the scatter of the next); then compounds 3 and 4 (each within the scatter of the next).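

In this assay, replacing methyl with bromo on this aromatic carbon gives a 1.3-fold higher number from compound 3 to compound 4 (0.12 log units; within the scatter), so the two groups cannot be told apart here. Compound 3 alone could not show whether the loss of growth inhibition belonged to methyl in particular, but bromo in place of hydrogen at the same carbon gives a 5.7-fold higher number from compound 1 to compound 4 (0.76 log units; beyond the scatter), which sits alongside a 4.3-fold higher number from compound 1 to compound 3 (0.63 log units; beyond the scatter). Two different single-atom replacements of hydrogen at this carbon, one carbon and one bromine, therefore both leave the number higher than that of compound 1, so the change seen with compound 3 is not unique to methyl.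

Nothing available explains why methyl and bromo read alike at this carbon or why either differs from hydrogen. The compounds shown leave open whether the higher number holds for every replacement of hydrogen here, since an amine, a hydroxyl, a methoxy group or a carboxylic acid on this carbon might give a number close to that of compound 1 or one further from it.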